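Swapping a Fluoro for a Methyl on a Phenylpiperazine

The compounds below may be only part of what the source reports. "The series", "measured", "known", "first", "only" and "open" are said of these compounds alone.

Measured compounds:
Compound 1 `CC1CCN(C(=S)SCc2ccc(C(=O)Nc3ccccc3N)cc2)CC1` gives 46.8%.
Compound 2 `Nc1ccccc1NC(=O)c1ccc(CSC(=S)N2CCN(c3ccc(F)cc3)CC2)cc1` gives 60.8%.
Compound 3 `COC(=O)c1ccc2c(c1)CCN2C(=S)SCc1ccc(C(=O)Nc2ccccc2N)cc1` gives 45.3%.

All three were tested in a functional assay on HeLa cells (Homo sapiens) for antiproliferative activity, read by CCK-8 assay, with a stated time of 72 h, tested at 2 uM; a lower number here means a weaker effect, a higher number a stronger effect of the compound at the concentration tested. Among them compound 2 stands highest. Its nearest neighbour is compound 1, whose number lies lower by a margin beyond the usual scatter, and compound 3 lies further below it, again beyond the scatter. No two of these compounds differ in only one place, so the three values show three different substituents on the thiocarbamoyl nitrogen without a single-point comparison between them.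

Compound 4 `Cc1ccc(N2CCN(C(=S)SCc3ccc(C(=O)Nc4ccccc4N)cc3)CC2)cc1` has not yet been measured in this assay. It differs from compound 2 in one place: methyl in place of fluoro on an aromatic carbon. Nothing in the measured set isolates this kind of swap, so no size for it has been observed. Because compound 2 gives 60.8% and the change is small, the expectation is a step of only modest size, in either direction or none beyond the scatter. The step from compound 2 to compound 4 is expected to be a number 5.8 percentage points lower from compound 2 to compound 4 (within the scatter). Compound 4 is accordingly estimated at 55%, within a range from 40% to 68%.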

Compound 4, a percentage reported as inhibition, at one concentration (the size of the read-out at that concentration, not a potency): 25.3%
Beside the measured number, compound 4's estimate is 29.7 percentage points above it; measured number outside the range, below it.
By their numbers in this assay, from the lowest: compound 4; then compounds 3 and 1 (each within the scatter of the next); then compound 2.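

In this assay, for the compounds shown here, the change from 4-fluorophenyl to 4-methylphenyl brings a number 35.5 percentage points lower from compound 2 to compound 4 (beyond the scatter) and so gives the first comparison in this set that isolates a single place. It shows that this aromatic carbon is not indifferent to what it carries: one heavy atom is exchanged for one heavy atom, neither group counts a hydrogen-bond donor or acceptor, and the read-out at this concentration still moves by a large margin. The finding rests on this one pair, so it fixes the size of this swap alone and sets no trend for other groups at this place. Nothing measured here accounts for the size of this step.

The compounds shown leave open what an unsubstituted phenyl, a chloro, a methoxy or an amine at this same carbon would give, and so whether the fluoro compound or the methyl compound is the exception among such groups. They also leave open whether the same swap carries a step of similar size when the rest of the molecule differs, or at other concentrations.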